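The source may hold more compounds than are shown below. What is called first, only, known or untested is meant among the compounds shown, and "the series" means these compounds.

Of the compounds shown here, two have been measured so far in a functional assay on MCF7 cells (Homo sapiens) for inhibition, read by CCK-8 assay, with a stated time of 48 h; a higher number here means a weaker inhibitor of growth, a lower number a stronger inhibitor of growth. Compound 1 `Cc1ccccc1Nc1nc(NCc2ccccc2)ncc1Cl` reaches only a limit of the assay, recorded as > 100000 nM. Within the data shown here, compound 2 `CN1CCN(c2ccc(Nc3ncc(Cl)c(Nc4ccccc4)n3)nc2)CC1` gives 51800 nM, the only true number available, so it is the sole quantitative reference point for the series. The two compounds do not differ in just one place, so no measured single change is available as a guide.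

Compound 3 `COc1ccc(CNc2nc(Nc3ccc(N4CCN(C)CC4)cn3)ncc2Cl)cc1` keeps the rest of compound 2 and changes one substituent: 4-methoxybenzyl in place of phenyl on a nitrogen on an aromatic ring. In words, 4-methoxybenzyl stands in place of phenyl on a nitrogen on an aromatic ring, which can also be read as anilino to (4-methoxybenzyl)amino.

With so little to go on, the expectation stays anchored to compound 2, measured at 51800 nM. A small gain in growth inhibition is expected in this assay, a 1.5-fold lower number from compound 2 to compound 3 (0.17 log units; within the scatter), and this may not clear the usual scatter. A result reported only as a limit also remains possible. For compound 3 the estimated value is 35000 nM, with an expected range from 10000 nM to 100000 nM.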

Compound 3, concentration for 50% growth inhibition: 17300 nM
For compound 3 the middle estimate is 2.0-fold (0.31 log units) above the measured one, within the range that was stated.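

Among these compounds, the step gives the first measured single change: at this nitrogen on an aromatic ring, going from anilino to (4-methoxybenzyl)amino gives, in this assay, a 3.0-fold lower number from compound 2 to compound 3 (0.48 log units; beyond the scatter), so growth inhibition here responds to what this nitrogen carries. The position also accepts the larger 4-methoxybenzyl group, which brings a hydrogen-bond acceptor that phenyl lacks, with no loss of growth inhibition. Compound 3 gives a true number that extends the quantitative scale beyond compound 2, while compound 1 alone remains a limit rather than a number: the limit of > 100000 nM in this assay, at which 1 of the 3 values shown sits.

The single step changes several things at once, so the compounds shown cannot say whether the gain belongs to the added carbon link, to the methoxy group or to both, and a plain benzyl or a 4-methoxyanilino group on this nitrogen would separate these two parts. Also open, going by these compounds, is whether a longer chain such as 2-phenylethyl, or an amine or a carboxylic acid in place of the methoxy group, would move the number further in either direction.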